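The source may hold more compounds than are shown below. What is called first, only, known or untested is meant among the compounds shown, and "the series" means these compounds.

Measured so far:
Compound 2 `O=C(CCN1C(=O)CSc2ccccc21)N1CCN(c2ccccc2)CC1`: in a functional assay on IMR-32 cells (Homo sapiens) for inhibition, read by sulforhodamine B assay, with a stated time of 48 h (a higher number here means a weaker inhibitor of growth, a lower number a stronger inhibitor of growth), compound 2 gives only the assay limit < 10 nM.
Compound 1 `O=C(CCN1C(=O)CSc2ccccc21)N1CCN(c2ccccc2F)CC1`: in this assay compound 1 gives only the assay limit > 100000 nM.

Compound 2 thus stands at the strong end of what this assay can report, and its number is a limit rather than a measured value (the limit of < 10 nM in this assay, at which 1 of the 2 values shown sits). Compound 3 `COc1ccccc1N1CCN(C(=O)CCN2C(=O)CSc3ccccc32)CC1` differs from compound 2 by a single change: methoxy in place of hydrogen on an aromatic carbon. Among the compounds with values here, one measured step bears on this place. The step of an at least 10000-fold lower number from compound 1 to compound 2 (4.00 log units; beyond the scatter) shows that a fluoro on that aromatic carbon, replaced by hydrogen, moved the number from one end of the assay to the other. Compound 1 sits at the weak limit (the limit of > 100000 nM in this assay, at which 1 of the 2 values shown sits). A methoxy at the same place, ortho to a large group, is therefore expected to cost potency, and a large step upward in this assay is expected, an at least 200-fold higher number from compound 2 to compound 3 (2.30 log units; beyond the scatter), though the starting point is itself only a limit. Compound 3 is accordingly estimated at 2000 nM, with a wide range from 20 nM to 100000 nM.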

Compound 3, concentration for 50% growth inhibition: > 100000 nM
Compound 3: a limit, no number; the forecaster's own chance of this, stated with the estimate: 30%; middle value at least 50-fold (1.69 log units) away from the limit.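

In this assay, methoxy in place of hydrogen on this aromatic carbon gives an at least 10000-fold higher number from compound 2 to compound 3 (4.00 log units; beyond the scatter), so the collapse seen with fluoro is no longer tied to a single group. Among the three compounds shown, the phenyl of compound 2 sits at the strong end of the assay, while both ortho-substituted rings sit at the weak end, which is a limit and not a number: the limit of > 100000 nM in this assay, at which 2 of the 3 values shown sit. The step between compound 1 and compound 3 cannot be read, so these data do not separate fluoro from methoxy at this place, and they show only that each one, in place of hydrogen, is enough to reach the weak limit.

On these data alone, it remains open whether any group at this place keeps the strong growth inhibition of compound 2, for example a methyl, a chlorine or a hydroxyl, or an amine or a carboxylic acid. As far as these compounds go, the true potency of compound 2 and the true weakness of compound 1 and compound 3 also stay hidden behind their limits in this assay, so the full size of the effect is unknown.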